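The source may hold more compounds than are shown below. What is called first, only, known or untested is meant among the compounds shown, and "the series" means these compounds.

Compound 1 `O=C(O)c1ccccc1-c1ccc(CCc2ncc(CC3CCC3)[nH]2)cc1`: 588 nM
Compound 2 `N#Cc1cccc(Cc2cnc(CCc3ccc(-c4ccccc4C(=O)O)cc3)[nH]2)c1`: 812 nM

In an in vitro functional assay on cells for agonist activity at Bombesin receptor subtype-3 (Homo sapiens), read by luminescence and calcium flux (a higher number here means that more compound is needed for the effect, a lower number that less compound is needed), compound 2 gives the highest of the two numbers, but its nearest neighbour, compound 1, lies within the scatter of it, so no order can be read between them. Compound 3 `O=C(O)c1ccccc1-c1ccc(CCc2ncc(Cc3ccccc3)[nH]2)cc1` is not yet measured. It differs from compound 2 in one place: hydrogen in place of cyano on an aromatic carbon. Among the compounds with values here, the only measured step that touches this part of the molecule is a 1.4-fold higher number from compound 1 to compound 2 (0.14 log units; within the scatter), which put 3-cyanophenyl in place of cyclobutyl on the saturated chain carbon and left the number within the scatter. That step exchanged a whole ring; the present one removes only the cyano, so a small movement in this assay is expected, with no direction beyond the scatter. Compound 3 is expected at 700 nM, between 300 nM and 1600 nM. For compound 3 the expected step is a 1.2-fold lower number from compound 2 to compound 3 (0.06 log units; within the scatter).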

Compound 3, half-maximal effective concentration: 205 nM
Estimate against measurement, compound 3: 3.4-fold (0.53 log units) above; the measured number lies below the stated range.
By their numbers in this assay, from the lowest: compound 3; then compounds 1 and 2 (each within the scatter of the next).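

In this assay, this position proves sensitive to a single substituent: a 4.0-fold lower number from compound 2 to compound 3 (0.60 log units; beyond the scatter), a change beyond the scatter, on removing only the cyano. The cyclobutyl comparison also reads differently with the unsubstituted ring: a 2.9-fold lower number from compound 1 to compound 3 (0.46 log units; beyond the scatter) for phenyl, beyond the scatter, whereas 3-cyanophenyl gave a 1.4-fold higher number from compound 1 to compound 2 (0.14 log units; within the scatter), within it. The benefit of an aromatic ring at this place therefore appears only without the cyano in this set, and nothing available gives a reason for the cyano's effect.

Still open, as far as these compounds go, is whether the higher number of compound 2 is specific to the nitrile or would also follow from a fluorine, a methoxy group or an amine on the same aromatic carbon. Also open, from the compounds shown here alone, is whether a longer chain carrying the phenyl would retain the number of compound 3.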